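Dropping the 1-methylethenyl group from the phenylpiperazine amide

The compounds below may be only part of what the source reports. "The series", "measured", "known", "first", "only" and "open" are said of these compounds alone.

The series is built on a shared core carrying a methyl-oxazole amide joined to a piperazine, with an aryl group on the far nitrogen. Among the measured compounds shown here, compound 1, `Cc1ccc(C)c(N2CCN(C(=O)c3oc(C)nc3-c3ccc(F)cc3)CC2)c1`, is the one member with a firm number: in a functional assay on HL-60 cells (Homo sapiens) for inhibition, read by MTT assay, with a stated time of 72 h (on this read-out lower numbers stand for stronger inhibition and higher numbers for weaker inhibition), compound 1 gives 358 nM. Compound 2, `C=C(C)c1ccc(N2CCN(C(=O)c3oc(C)nc3-c3ccccc3)CC2)cc1`, stands on no single number, since in this assay compound 2 is reported only as "not active" (no number reported); it therefore gives no anchor from which a step could be measured.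

Compound 3, `Cc1nc(-c2ccccc2)c(C(=O)N2CCN(c3ccccc3)CC2)o1`, differs from compound 2 by one change: hydrogen in place of 1-methylethenyl on an aromatic carbon The difference, cut one bond further out, reads 4-(1-methylethenyl)phenyl to phenyl, at an aromatic carbon of a six-membered aromatic ring of carbon only, para to a large group.

For the measured compounds named here, because no step between measured compounds exists in this set, the size of the move from compound 2 to compound 3 in this assay cannot be read off directly, and with compound 2 lacking a number the direction is open as well. The author expects compound 3 to remain weak, with an estimated value of 8000 nM, in a range from 1500 nM to 40000 nM.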

Compound 3, half-maximal inhibitory concentration: 39.1 nM
Estimate against measurement, compound 3: 200-fold (2.31 log units) above; the whole stated range lies above it.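

No step can be read between compound 2 and compound 3: in this assay compound 2 carries only the report "not active", with no number. The compounds shown leave open how large a change in inhibition goes with replacing 1-methylethenyl by hydrogen. No evidence at hand bears on this result.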